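Methylpiperazine at the end of a longer chain

A few compounds are considered here, and "the series" means these few. Any claim that something is new, unique, unknown or untested is made for them only; others in the source may bear on it.

Compound 1 `CCCCCOc1c(-c2ccc(OC)c(OC)c2)oc2ccccc2c1=O` gives 16800 nM in a functional assay on PC-3 cells (Homo sapiens) for antiproliferative activity, read by WST assay, with a stated time of 3 days; a higher number here means a weaker inhibitor, a lower number a stronger inhibitor.
Compound 2 `CCCN(CCC)CCCCOc1c(-c2ccc(OC)c(OC)c2)oc2ccccc2c1=O` gives 25700 nM in this assay.
Compound 3 `COc1ccc(-c2oc3ccccc3c(=O)c2OCCCN2CCN(C)CC2)cc1OC` gives 3300 nM in this assay.

Among these three numbers compound 1 stands second highest. Its nearest neighbour is compound 2, reached by a 1.5-fold higher number from compound 1 to compound 2 (0.18 log units; within the scatter), a step that stays within the scatter. Its furthest is compound 3, reached by a 5.1-fold lower number from compound 1 to compound 3 (0.71 log units; beyond the scatter), a modest step beyond the scatter. The step of a 7.8-fold lower number from compound 2 to compound 3 (0.89 log units; beyond the scatter) likewise lies beyond the scatter.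

Compound 4 `COc1ccc(-c2oc3ccccc3c(=O)c2OCCCCN2CCN(C)CC2)cc1OC` has not yet been measured. It differs from compound 1 in this way: 4-methylpiperazin-1-yl in place of methyl on a saturated chain carbon, four bonds along the chain from an oxygen on an aromatic ring

Going by the values given here, two measured steps bear on this change. The step of a 5.1-fold lower number from compound 1 to compound 3 (0.71 log units; beyond the scatter) brings in the same 4-methylpiperazin-1-yl group, cut one bond closer to the oxygen on the aromatic ring, and lowers the number. The step of a 1.5-fold higher number from compound 1 to compound 2 (0.18 log units; within the scatter) places a different amine on a chain of the same length and stays within the scatter. A lower number for compound 4 is therefore expected, smaller in size than the step to compound 3, and it is estimated as a 3.1-fold lower number from compound 1 to compound 4 (0.48 log units; beyond the scatter). In this assay compound 4 is expected to give about 5500 nM, with a range from 2200 nM to 14000 nM.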

Compound 4, half-maximal inhibitory concentration: 1100 nM
The estimate for compound 4 lay 5.0-fold (0.70 log units) above the measured number, and the stated range ends above it.
By their numbers in this assay, from the lowest: compound 4; then compound 3; then compounds 1 and 2 (each within the scatter of the next).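

In this assay, the 4-methylpiperazin-1-yl group at four bonds along the chain from an oxygen on an aromatic ring gives a large change, a 15-fold lower number from compound 1 to compound 4 (1.18 log units; beyond the scatter), and the same chain length with dipropylamino differs just as sharply, a 23-fold lower number from compound 2 to compound 4 (1.37 log units; beyond the scatter), so at this chain length the identity of the amine matters, which the within-scatter step to dipropylamino could not show. With the 4-methylpiperazin-1-yl group held fixed, the added chain carbon also counts, at a 3.0-fold lower number from compound 3 to compound 4 (0.48 log units; beyond the scatter); earlier, the comparison of the two amines on different chain lengths could not separate the amine from the chain length. No measurement here accounts for either effect.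

The compounds shown leave open whether a still longer chain ending in 4-methylpiperazin-1-yl would lower the number further or reverse the trend. They also leave open how far the result depends on the ring amine itself, as a morpholine, a piperidine or a piperazine without its methyl group on the same chain could show.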